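Bromo step on compound 2: cytotoxicity expected near limit

The compounds below may be only part of what the source reports. "The series", "measured", "known", "first", "only" and "open" are said of these compounds alone.

Measured in a functional assay on HeLa cells (Homo sapiens) for cytotoxicity, read by cell counting, with a stated time of 72 h (on this read-out lower numbers stand for stronger inhibition and higher numbers for weaker inhibition), each value being a limit:
- compound 1 `Clc1ncc2sccc2n1` gives > 250000 nM as a limit
- compound 2 `Clc1nc(-n2cncn2)c2sccc2n1` gives > 250000 nM as a limit
- compound 3 `O=c1[nH]c(=O)c2scc(Br)c2[nH]1` gives > 250000 nM as a limit

Compound 2 stands only at a limit, > 250000 nM in this assay, and offers no number to step from. For the measured compounds named here, the whole series so far rests on (the limit of > 250000 nM in this assay, at which 3 of the 3 values shown sit), so no measured compound supplies a number. Going to compound 4 `Clc1nc(-n2cncn2)c2scc(Br)c2n1`, the change is bromo in place of hydrogen on an aromatic carbon and nothing else.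

Going by the values given here, the one measured step, a step that the two limits leave unreadable from compound 1 to compound 2, cannot be sized and gives no guide. Among the compounds with values here, compound 3 is the only measured compound carrying a bromo group, and compound 3 gives > 250000 nM, again a limit. No measured step sizes a bromo change, so only a weak expectation is possible in this assay: a small move or none, with any readable move toward stronger inhibition. A further report of only a limit is about as likely as a number. The expected step is an at least 2.0-fold lower number from compound 2 to compound 4 (0.31 log units; beyond the scatter), an estimate only. The estimate for compound 4 is 120000 nM, expected to fall within 10000 nM to 250000 nM for a numerical reading.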

Compound 4, half-maximal inhibitory concentration: 116000 nM
Compound 4: middle estimate off by 1.0-fold (0.01 log units), on the high side; the range from low to high includes it.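

Bromo in place of hydrogen on an aromatic carbon, two ring bonds from the ring sulfur, is the only readable step so far in this assay: an at least 2.1-fold lower number from compound 2 to compound 4 (0.33 log units; beyond the scatter). Compound 3 also carries a bromo group and gives > 250000 nM, which is a limit; it differs from compound 4 in more than one place, so no step can be read from it. Compound 4 is the only compound shown with a numerical reading, so the series offers no second number to set beside it: the limit of > 250000 nM in this assay, at which 3 of the 4 values shown sit.

Still open, going by these compounds, is whether a methyl group or an amine in the same place on the five-membered ring would also give a reading, and how such a reading would compare with that of compound 4. The step from compound 1 to compound 2 cannot be read, so the part played by the 1H-1,2,4-triazol-1-yl group in the reading of compound 4 also remains unsettled.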